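The source may report more compounds than this note shows. Statements on the series, on what has been measured and on what is new or still open speak of the compounds shown alone.

For the measured compounds named here, in a functional assay (aorta) for inhibition, with Rattus norvegicus as the target (on this read-out lower numbers stand for stronger inhibition and higher numbers for weaker inhibition), compound 1 `CC(C)/N=C(\S)[C@]1(c2cccnc2)CCCC[S+]1[O-]` gives 10000 nM, the one firm number available. Compound 2 `[O-][S+]1CCCC[C@]1(/C(S)=N/c1ccccc1)c1cccnc1` sits at a limit of the assay, > 30000 nM. Going by the values given here, the sole measured step, an at least 3.0-fold higher number from compound 1 to compound 2 (0.47 log units; beyond the scatter), changes only the group on the double-bonded nitrogen, and inhibition weakens. Compound 3 `[O-][S+]1CCCC[C@]1(CS)c1cccnc1` goes further: a group of 2 heavy atoms (1 carbon, 1 sulfur; no ring) in place of a group of 6 heavy atoms (4 carbon, 1 nitrogen, 1 sulfur; no ring), on a saturated ring carbon, on a saturated ring carbon, so the double-bonded nitrogen is gone altogether. With that single step as the guide, a modest move towards weaker inhibition is expected, an estimated 2.0-fold higher number from compound 1 to compound 3 (0.30 log units; within the scatter). For compound 3 the estimated value is 20000 nM, within a range of 6000 nM to 70000 nM.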

Compound 3, concentration for 90% inhibition: > 30000 nM
Compound 3 ended at the assay's limit; the forecaster's own chance of this, stated with the estimate: 45%; middle value at least 1.5-fold (0.17 log units) from the limit.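

Swapping the larger group on the saturated ring carbon for sulfanylmethyl gives an at least 3.0-fold higher number from compound 1 to compound 3 (0.47 log units; beyond the scatter). Compound 3 sits at a limit of the assay, > 30000 nM. So a sulfur-bearing group at this position does not, on its own, match compound 1 once the double-bonded nitrogen and its isopropyl are gone.

On these data alone, how far inhibition really falls stays open, and only compound 1 offers a firm number: the limit of > 30000 nM in this assay, at which 2 of the 3 values shown sit. Whether a cyclohexyl on that nitrogen, or an amine on the ring carbon, would give stronger inhibition than compound 1 is also unknown.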